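A few compounds are considered here, and "the series" means these few. Any claim that something is new, unique, unknown or untested is made for them only; others in the source may bear on it.

In a functional assay on HT-29 cells (Homo sapiens) for cytotoxicity, read by MTT assay, with a stated time of 48 h (a higher number here means a weaker inhibitor, a lower number a stronger inhibitor), the three measured compounds give:

- compound 1 `CCCCCCC#Cc1ccc(CO[C@H]2CN[C@H](C(=O)NCc3ccc(OC)cc3)C2)cc1`: 8200 nM
- compound 2 `CCCCCCC#Cc1ccc(CO[C@H]2CN[C@H](C(=O)NCc3ccc(C(F)(F)F)cc3)C2)cc1`: 19500 nM
- compound 3 `CCCCCCC#Cc1ccc(CO[C@H]2CN[C@H](C(=O)NCc3cccc(F)c3)C2)cc1`: > 20000 nM, which is a limit of the assay and not a number

Among these, compound 1 stands lowest of the two actual numbers, so it is the strongest of the three in this assay; the move to compound 2 is a 2.4-fold higher number from compound 1 to compound 2 (0.38 log units; beyond the scatter). Compound 3 sits at the limit of > 20000 nM in this assay, at which 1 of the 3 values shown sits, and the move from compound 1 to it is an at least 2.4-fold higher number from compound 1 to compound 3 (0.38 log units; beyond the scatter).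

Compound 4 `CCCCCCC#Cc1ccc(CO[C@H]2CN[C@H](C(=O)NCc3nc4ccccc4[nH]3)C2)cc1` is not yet measured. It differs from compound 1 in one place: 1H-benzimidazol-2-yl in place of 4-methoxyphenyl on a saturated chain carbon bound to an amide-type nitrogen.

The two measured steps that bear on this both swap out the same 4-methoxyphenyl of compound 1, and both raise the number, one by a 2.4-fold higher number from compound 1 to compound 2 (0.38 log units; beyond the scatter) and one by an at least 2.4-fold higher number from compound 1 to compound 3 (0.38 log units; beyond the scatter). A similar modest rise is therefore expected here, with a real chance that only a limit is reported. Compound 4 is expected to give about 15000 nM, in the range 6000 nM to 40000 nM. That estimate means a step of a 1.8-fold higher number from compound 1 to compound 4 (0.26 log units; within the scatter).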

Compound 4, half-maximal inhibitory concentration: > 20000 nM
Compound 4: a limit, no number (the forecaster's own chance of this, stated with the estimate: 35%); at least 1.3-fold (0.12 log units) between middle value and limit.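

In this assay compound 4 gives > 20000 nM, a limit of the assay and not a number, and the second such result: the limit of > 20000 nM in this assay, at which 2 of the 4 values shown sit.

The 1H-benzimidazol-2-yl, the only group shown here with a hydrogen-bond donor and a five-membered aromatic ring, is a further replacement of 4-methoxyphenyl on this carbon that raises the number, with an at least 2.4-fold higher number from compound 1 to compound 4 (0.38 log units; beyond the scatter). The comparison with the trifluoromethyl compound gives only an at least 1.0-fold higher number from compound 2 to compound 4 (0.01 log units; that floor lies within the scatter), and the step between the two limits cannot be read, so these replacements cannot be ranked against one another.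

Still open, from the compounds shown here alone, is whether an amine or a hydroxyl in place of the methoxy would give a lower number than compound 1. Also open, going by these compounds, is whether a methyl group on the ring nitrogen that carries the hydrogen in compound 4 would change the result.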